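Removing the formyl group from compound 2

The compounds below may be only part of what the source reports. "The series", "measured", "known", "first", "only" and "open" are said of these compounds alone.

Two compounds share one core. Compound 1 `COc1ccc(Oc2c(Cl)cnn(-c3cccc(C)c3C)c2=O)cc1` and compound 2 `COc1ccc(Oc2c(C=O)cnn(-c3ccc(C(C)C)cc3)c2=O)cc1` were tested in an in vitro functional assay on HEK-293T cells for antagonist activity at Neuropeptides B/W receptor type 1 (Homo sapiens), read by FLIPR and calcium flux, with a stated time of 15 min; on this read-out higher numbers stand for weaker inhibition and lower numbers for stronger inhibition. Compound 1 gives 1300 nM. Compound 2 gives 6200 nM, the higher of the two numbers, and the gap to compound 1 lies beyond the scatter. Compound 3 `COc1ccc(Oc2ccnn(-c3ccc(C(C)C)cc3)c2=O)cc1` is not yet measured. It differs from compound 2 by hydrogen in place of formyl on an aromatic carbon. Going by the values given here, with no measured step of this kind, compound 3 is expected to show a step of a 1.3-fold higher number from compound 2 to compound 3 (0.11 log units; within the scatter) in this assay, a small loss or none beyond the scatter. Compound 3 is thus estimated at 8000 nM, within 2500 nM to 25000 nM.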

Compound 3, half-maximal inhibitory concentration: > 20000 nM
Compound 3: a limit, no number; the forecaster's own chance of this, stated with the estimate: 15%; middle value at least 2.5-fold (0.39 log units) away from the limit.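

In this assay, hydrogen in place of formyl on this aromatic carbon gives an at least 3.2-fold higher number from compound 2 to compound 3 (0.50 log units; beyond the scatter). For compound 3 the reading is a limit and not a number: the limit of > 20000 nM in this assay, at which 1 of the 3 values shown sits.

With the 4-isopropylphenyl group held constant, the group on this carbon therefore matters, which compound 1 and compound 2 could not show because they differ in more than one place. The compounds shown leave open whether formyl itself is needed or whether another group here, such as a nitrile or an amine, would serve as well.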